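Adding a Second Bromine to a Cytotoxicity-Tolerant Amide

A few compounds are considered here, and "the series" means these few. Any claim that something is new, unique, unknown or untested is made for them only; others in the source may bear on it.

Compound 1 `COc1c(Br)cccc1C(=O)Nc1ccc(Sc2nc3ccccc3s2)c(Cl)c1` was tested in an ADME assay on HEK293 cells (Homo sapiens) for cytotoxicity, read by reporter gene assay and resazurin assay, with a stated time of 48 h; a higher number here means that more compound is tolerated, a lower number that less compound is tolerated. Compound 1 reaches only the limit of the measurement there, > 100000 nM, so its true value is not known as a number. Compound 2 `O=C(Nc1cccc(Cl)c1)c1cc(Br)cc(Br)c1O` was also measured in this assay, and compound 2 gives 18000 nM. Among the measured compounds shown here, no single-point step joins these two compounds, so their values can only be set side by side: one sits at the limit of > 100000 nM in this assay, at which 1 of the 2 values shown sits, and the other gives a number. Compound 3 `COc1c(Br)cc(Br)cc1C(=O)Nc1ccc(Sc2nc3ccccc3s2)c(Cl)c1` is compound 1 with one change: bromo in place of hydrogen on an aromatic carbon, placed meta to a bromo group and para to a methoxy group. For the measured compounds named here, no measured step shows what such a change does here, so a step in this assay beyond the scatter is not expected in either direction. Compound 3 is therefore expected to give about 100000 nM, within 40000 nM to 250000 nM, and most likely again only a limit. The step of a number no higher from compound 1 to compound 3 (the limit leaves the size open) is expected to be essentially none.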

Compound 3, half-maximal cytotoxic concentration: > 100000 nM
Compound 3 was reported as a limit; the forecaster's own chance of this, stated with the estimate: 70%; the middle value sits exactly at the limit.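

Among the compounds shown here, compound 1 and compound 3 are both reported only as limits in this assay, so no step between them can be read. On these data alone, whether the added bromo changes the tolerated concentration at all stays open, as do the true values of both compounds.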